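Methoxyphenyl placement in two vinyl ketone cores

The source may report more compounds than this note shows. Statements on the series, on what has been measured and on what is new or still open speak of the compounds shown alone.

Compounds 1 and 2 share one core, compounds 3 and 4 another; how the two cores differ is not broken down here. Compound 1 `COc1ccccc1/C=C(\C(=O)c1ccc(Cl)cc1)S(=O)(=O)c1ccc(Br)cc1` and compound 2 `COc1ccc(/C=C(\C(=O)c2ccc(Cl)cc2)S(=O)(=O)c2ccc(Br)cc2)cc1` differ by 4-methoxyphenyl in place of 2-methoxyphenyl on a double-bonded chain carbon bound to a double-bonded chain carbon. In a functional assay on DU-145 cells (Homo sapiens) for inhibition, read by trypan blue exclusion, with a stated time of 96 h (on this read-out higher numbers stand for weaker inhibition of growth and lower numbers for stronger inhibition of growth), compound 1 gives 10000 nM and compound 2 gives 10000 nM; the step of no change at the digits printed from compound 1 to compound 2 (within the scatter), so moving the methoxy group did not shift the read-out in this pair. Compound 3 `COc1ccccc1/C=C(/Sc1ccc(C)cc1)C(=O)c1ccc(Cl)cc1` gives 25000 nM in this assay, the highest number of the three measured, beyond the scatter relative to both compound 1 and compound 2. Compound 4 `COc1ccc(/C=C(/Sc2ccc(C)cc2)C(=O)c2ccc(Cl)cc2)cc1` is not yet measured; it differs from compound 3 by 4-methoxyphenyl in place of 2-methoxyphenyl on a double-bonded chain carbon bound to a double-bonded chain carbon, the same change as from compound 1 to compound 2, made at the same place on a double-bonded chain carbon bound to a double-bonded chain carbon. Among the measured compounds shown here, the one precedent for this change, the step of no change at the digits printed from compound 1 to compound 2 (within the scatter), gives no reason to expect movement, and the step from compound 3 to compound 4 is therefore estimated to be no change at the digits printed from compound 3 to compound 4 (within the scatter). Compound 4 is expected to give about 25000 nM in this assay, with a plausible range of 12000 nM to 50000 nM.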

Compound 4, concentration for 50% growth inhibition: 1000 nM
For compound 4 the middle estimate is 25-fold (1.40 log units) above the measured one; measured number outside the range, below it.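

In this assay, 4-methoxyphenyl in place of 2-methoxyphenyl on a double-bonded chain carbon bound to a double-bonded chain carbon gives a 25-fold lower number from compound 3 to compound 4 (1.40 log units; beyond the scatter), whereas the same change on the other core gives no change at the digits printed from compound 1 to compound 2 (within the scatter). The effect of this change therefore does not carry from one core to the other in this series: the same change on two cores in this assay, no change at the digits printed (within the scatter) from compound 1 to compound 2 and a 25-fold lower number (1.40 log units; beyond the scatter) from compound 3 to compound 4, 25-fold (1.40 log units) apart, beyond the scatter of two such steps

This shows that the core can decide whether the change matters, but with a single pair on each core it does not show which part of the core is responsible, or whether the large step would recur on a further core.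

Open is which of the differences between the two cores sets the two steps apart, as the pairs shown do not take those differences one at a time. Also open, going by these compounds, is whether the lower number on the core of compound 3 is specific to the methoxy group, or would persist with a hydroxyl group, an amine or a carboxylic acid in its place.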